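Thiophen-2-yl for methyl on the shared core of compound 1

A few compounds are considered here, and "the series" means these few. Any claim that something is new, unique, unknown or untested is made for them only; others in the source may bear on it.

Compound 1 `Cc1nc(Cl)ncc1C(=O)Nc1cc(C(F)(F)F)cc(C(F)(F)F)c1` is the reference point of the series. In an assay on Jurkat cells for activation of nuclear factor NF-kappa-B complex (Homo sapiens) (a lower number here means a stronger inhibitor, a higher number a weaker inhibitor), compound 1 gives 50 nM, the lowest of the two numbers in hand. Compound 3 `O=C(Nc1cc(C(F)(F)F)cc(C(F)(F)F)c1)c1ccc(Cl)nn1` gives 1700 nM in this assay. Compound 2 `Cc1nc(C(F)(F)F)ncc1C(=O)Nc1cc(C(F)(F)F)cc(C(F)(F)F)c1` gives > 10000 nM in this assay, a limit rather than a number: the limit of > 10000 nM in this assay, at which 1 of the 3 values shown sits.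

Both measured steps leave compound 1 and both lose: an at least 200-fold higher number from compound 1 to compound 2 (2.30 log units; beyond the scatter), and a 34-fold higher number from compound 1 to compound 3 (1.53 log units; beyond the scatter). Each touches the shared core, though neither is the change now in question, and neither alters the methyl.

Compound 4 `O=C(Nc1cc(C(F)(F)F)cc(C(F)(F)F)c1)c1cnc(Cl)nc1-c1cccs1` differs from compound 1 by thiophen-2-yl in place of methyl on an aromatic carbon. Among the measured compounds shown here, no measured step tests this position. What the two steps do show is that the core of compound 1 tolerates neither the one-atom swap on it nor its replacement, so a further change on it, by a larger group ortho to the amide carbonyl, is expected to cost rather than gain, though less surely than the measured losses. The expected step is an 8.0-fold higher number from compound 1 to compound 4 (0.90 log units; beyond the scatter). Compound 4 is therefore estimated at 400 nM, with a range from 60 nM to 4000 nM in this assay.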

Compound 4, half-maximal inhibitory concentration: 9800 nM
Compound 4: middle estimate off by 25-fold (1.39 log units), on the low side, outside the stated range (above it).
By their numbers in this assay, from the lowest: compound 1; then compound 3; then compound 4. At a limit, above all of these: compound 2.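

Among the compounds shown here, the methyl of compound 1 now has a direct test for the first time: in this assay, thiophen-2-yl on this aromatic carbon gives a 200-fold higher number from compound 1 to compound 4 (2.29 log units; beyond the scatter). The earlier steps changed the chloro group or replaced the whole chloro-bearing ring part and left the methyl in place, so they showed nothing about this carbon; it now joins them as a third place on the shared core where the one change shown brings a large loss, and no step shown from compound 1 yet gives a gain. Compound 2 is the only compound here whose value is a limit and not a number: the limit of > 10000 nM in this assay, at which 1 of the 4 values shown sits.

Still open is whether the loss belongs to the thiophen-2-yl ring itself or to any group with more heavy atoms than methyl on this carbon, as only one replacement is shown here. As far as these compounds go, a hydrogen, an ethyl group, a phenyl ring or an amine at this place would separate those readings, and it also remains unknown whether the loss would persist with a group other than chloro on the shared core.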